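This account rests on a few compounds, and the source may have more. Where it says the series, first, only, none or still open, it means among the compounds named here.

Working notes on the series. The shared core is that of compound 1 `CC1=CC[C@H](C(C)(C)NC(=S)N/N=C/c2ccc(O)cc2)CC1`; the other members are compound 2 `CC1=CC[C@H](C(C)(C)NC(=S)N/N=C/c2ccc(N(C)C)cc2)CC1`, compound 3 `CC1=CC[C@H](C(C)(C)NC(=S)N/N=C/c2cccc([N+](=O)[O-])c2)CC1` and the unmeasured compound 4 `CC1=CC[C@H](C(C)(C)NC(=S)N/N=C/c2cccs2)CC1`. In a functional assay on U-251 cells (Homo sapiens) for inhibition, read by sulforhodamine B assay, with a stated time of 48 h (on this read-out higher numbers stand for weaker inhibition of growth and lower numbers for stronger inhibition of growth), compound 1 gives only a limit, > 100000 nM, not a number. Compound 3 likewise returns a limit, > 100000 nM. Compound 2 gives a number, 57700 nM. Going by the values given here, the one step between measured compounds that differ in a single place, an at least 1.7-fold lower number from compound 1 to compound 2 (0.23 log units; that floor lies within the scatter), moves from a limit to a number, and its floor lies within the scatter; both limits are the same bound, (the limit of > 100000 nM in this assay, at which 2 of the 3 values shown sit). Compound 1 thus stands at the edge of what this assay reports, with no numeric value of its own.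

The change to compound 4 is thiophen-2-yl in place of 4-hydroxyphenyl on a carbon with a double bond to nitrogen. Among the compounds with values here, no measured step covers exchange of the whole aryl group for a five-membered ring; the only measured step, between compound 1 and compound 2, concerns a substituent on the six-membered ring and was modest at most. Within the data shown here, nothing among the measured compounds points to a large gain, so the expected step of an at least 1.2-fold lower number from compound 1 to compound 4 (0.09 log units; that floor lies within the scatter) is small or none beyond the scatter, in either direction. Compound 4 is therefore estimated at 80000 nM, with a range from 30000 nM to 300000 nM, and a real chance that this assay again returns only a limit.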

Compound 4, concentration for 50% growth inhibition: 13500 nM
The estimate for compound 4 lay 5.9-fold (0.77 log units) above the measured number, outside the stated range (below it).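

Going by these compounds alone, the step, an at least 7.4-fold lower number from compound 1 to compound 4 (0.86 log units; beyond the scatter), is the first that lies beyond the scatter, and it comes from exchanging the whole aromatic group on a carbon with a double bond to nitrogen, not from changing a substituent on the six-membered ring. In this assay compound 2 gives 57700 nM and compound 4 gives 13500 nM, so of the two members with a number, the one carrying thiophen-2-yl has the lower. This step is only a floor, and its full size cannot be read, because compound 1 has only a limit and no number of its own: the limit of > 100000 nM in this assay, at which 2 of the 4 values shown sit.

4-hydroxyphenyl and thiophen-2-yl differ at once in ring size, in the hetero atom and in the hydrogen-bond donor, and the compounds shown do not separate these three differences. Furan-2-yl in the same place would test whether the sulfur of the ring matters or the five-membered ring alone is enough, and an unsubstituted phenyl would show what the hydroxy group contributes on its own.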